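This account rests on a few compounds, and the source may have more. Where it says the series, first, only, none or still open, it means among the compounds named here.

Three compounds share one core and differ only in the group on the six-membered aromatic ring with two nitrogens. In an assay on cells for inhibition of cytochrome P450 11B2, mitochondrial (Homo sapiens), read by HPLC, with a stated time of 90 min (on this read-out higher numbers stand for weaker inhibition and lower numbers for stronger inhibition), compound 1 `Cc1ncncc1-c1nc2cc(F)c(F)cc2n1C1CC1` gives 17 nM, compound 2 `CCc1ncncc1-c1nc2cc(F)c(F)cc2n1C1CC1` gives 8 nM, and compound 3 `CC(C)c1ncncc1-c1nc2cc(F)c(F)cc2n1C1CC1` gives 5 nM, the lowest of the three numbers, though compound 2 lies within the scatter of it. Among the compounds with values here, the steps so far are a 2.1-fold lower number from compound 1 to compound 2 (0.33 log units; beyond the scatter), a 3.4-fold lower number from compound 1 to compound 3 (0.53 log units; beyond the scatter) and a 1.6-fold lower number from compound 2 to compound 3 (0.20 log units; within the scatter): a larger group at that place brings a lower number, but the last of these steps stays within the scatter. Compound 4 `Fc1cc2nc(-c3cncnc3C3CC3)n(C3CC3)c2cc1F` carries cyclopropyl in place of isopropyl on an aromatic carbon. Within the data shown here, no measured step covers a ring of this kind at that place, and the earlier gains are already flattening, so compound 4 is expected to show no change at the digits printed from compound 3 to compound 4 (within the scatter). The estimate for compound 4 in this assay is 5 nM, within a range from 2 nM to 12 nM.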

Compound 4, half-maximal inhibitory concentration: 172 nM
For compound 4 the middle estimate is 34-fold (1.54 log units) below the measured one; measured number outside the range, above it.
By their numbers in this assay, from the lowest: compounds 3 and 2 (each within the scatter of the next); then compound 1; then compound 4.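

Replacing isopropyl with cyclopropyl keeps the count of heavy atoms and adds only a three-membered ring, yet it gives a 34-fold higher number from compound 3 to compound 4 (1.54 log units; beyond the scatter), so at this position the heavy-atom count alone does not set the number. The ring also compares poorly with the smaller chains, with a 22-fold higher number from compound 2 to compound 4 (1.33 log units; beyond the scatter) and a 10-fold higher number from compound 1 to compound 4 (1.01 log units; beyond the scatter), making compound 4 the exception to the trend among compounds 1, 2 and 3. No measurement here accounts for this jump.

Going by these compounds, whether a larger ring such as cyclobutyl would behave like cyclopropyl remains open. So does the outcome for tert-butyl, a longer chain or an amine at this position.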